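Trimming the anilide ethyl of compound 1 to methyl

A few compounds are considered here, and "the series" means these few. Any claim that something is new, unique, unknown or untested is made for them only; others in the source may bear on it.

Measured compounds:
compound 1 `CCc1cccc(NC(=O)CN2CCN(c3ccccn3)CC2)c1` gives 28.7 nM
compound 2 `Cc1ccc(C2CCN(CC(=O)Nc3cccc(C)c3)CC2)cc1` gives "not active" (no number reported)
compound 3 `Cc1cccc(NC(=O)CN2CCC(c3ccc(Cl)cc3)CC2)c1` gives "not active" (no number reported)

Within the data shown here, in a functional assay on cells for agonist activity at D(4) dopamine receptor (Homo sapiens), read by TR-FRET and cAMP accumulation, with a stated time of 30 min (on this read-out higher numbers stand for an effect only at larger amounts of compound and lower numbers for an effect already at smaller amounts), compound 1 is the only compound of the set with a reported number, at 28.7 nM. Compound 2 and compound 3, which carry a different core than compound 1, are reported without a number in this assay, so nothing can be read from them about the step now considered.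

The unmeasured compound 4 `Cc1cccc(NC(=O)CN2CCN(c3ccccn3)CC2)c1` differs from compound 1 in a single place: hydrogen in place of methyl on a saturated chain carbon bound to an aromatic carbon, reading ethyl to methyl, or 3-ethylphenyl to 3-methylphenyl.

Among the measured compounds shown here, no measured pair shows this change, so the size of the step cannot be drawn from the data; a small one, within or at the edge of the usual scatter, is expected, the step from compound 1 to compound 4 being estimated at a 1.6-fold higher number from compound 1 to compound 4 (0.20 log units; within the scatter). Compound 4 is therefore expected to give about 45 nM, in a range from 15 nM to 150 nM.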

Compound 4, half-maximal effective concentration: 3.6 nM
Beside the measured number, compound 4's estimate is 13-fold (1.10 log units) above it; measured number below the stated range.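

In this assay, among these compounds, the change from 3-ethylphenyl to 3-methylphenyl on the shared core gives an 8.0-fold lower number from compound 1 to compound 4 (0.90 log units; beyond the scatter), the first step that can be read at this place. It shows that the group on the aromatic ring is not a neutral detail here: the loss of a methyl from the saturated chain carbon bound to an aromatic carbon, with nothing else changed, moves the number beyond the usual scatter, towards effect at smaller amounts of compound. This rests on one pair only, and nothing given here accounts for the size of the step.

What the compounds shown leave open is how a longer chain such as propyl, or a methoxy group, would read at this place. They also leave open whether the same step would appear on a different core.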